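Oxazolidinone Series: Solubility Before and After a Side-Chain Swap

A few compounds are considered here, and "the series" means these few. Any claim that something is new, unique, unknown or untested is made for them only; others in the source may bear on it.

Measured compounds:
compound 1, `O=C1O[C@@H](CN2CCC(c3ccc(F)cc3)CC2)CN1c1ccc(-n2cc(-c3ccccn3)cn2)c(F)c1`, in a physicochemical assay for solubility, read by HPLC, with a stated time of 24 h; on this read-out higher numbers stand for higher solubility and lower numbers for lower solubility: <= 19400 nM, which is a limit of the assay and not a number
compound 2, `O=C1CCC(=O)N1C[C@H]1CN(c2ccc(-n3cc(-c4ccccn4)cn3)c(F)c2)C(=O)O1`, in this assay: 45300 nM

Within the data shown here, compound 2 stands as the only compound with a plain number in this assay. Among the measured compounds shown here, the value of compound 1 in this assay is a limit of the assay, as noted in the limit of <= 19400 nM in this assay, at which 1 of the 2 values shown sits, and no step between the two can be counted from it.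

Compound 3, `O=C1O[C@@H](CSc2cccs2)CN1c1ccc(-n2cc(-c3ccccn3)cn2)c(F)c1`, has not yet been measured. It differs from compound 2 in one place: (thiophen-2-yl)sulfanyl in place of 2,5-dioxopyrrolidin-1-yl on a saturated chain carbon bound to a saturated ring carbon. For the measured compounds named here, no measured step of this kind is available, so the expectation rests on the structural change alone. The solubility of compound 3 is expected to move downward from that of compound 2, by a step estimated as a 7.6-fold lower number from compound 2 to compound 3 (0.88 log units; beyond the scatter), larger than the scatter of repeats. The estimate for compound 3 in this assay is 6000 nM, with a range from 1200 nM to 30000 nM.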

Compound 3, solubility: 8500 nM
Beside the measured number, compound 3's estimate is 1.4-fold (0.15 log units) below it; measured number inside the range.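

The position on a saturated chain carbon bound to a saturated ring carbon now gives its first readable step in this assay: a 5.3-fold lower number from compound 2 to compound 3 (0.73 log units; beyond the scatter), with (thiophen-2-yl)sulfanyl in place of 2,5-dioxopyrrolidin-1-yl. Both groups carry no net charge and have equal counts of hydrogen-bond donors and acceptors, so the step comes with no change in those counts, and the read-out at this position still moves beyond the scatter. Compound 1 holds a limit of the assay and not a number, and steps to it cannot be read: the limit of <= 19400 nM in this assay, at which 1 of the 3 values shown sits.

Nothing shown here tells why the number moved between these two groups. Going by these compounds, it also remains open whether the sulfanyl link or the thiophene ring carries the step, and what an amine, a carboxylic acid or a longer chain at this place would give in this assay.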